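From Amide to Urea at the Urotensin-2 Receptor

The source may report more compounds than this note shows. Statements on the series, on what has been measured and on what is new or still open speak of the compounds shown alone.

Measured compounds:
compound 1 `Cc1cccc(C(=O)NC(CCN(C)C)c2ccc(Cl)cc2)c1C`: 159%
compound 2 `CN(C)CCC(OC(=O)Nc1ccc(-c2ccccc2)cc1)c1ccc(Cl)cc1`: 58%
compound 3 `COc1cccc(NC(=O)OC(CCN(C)C)c2ccc(Cl)cc2)c1`: 136%

In an assay on NIH3T3 cells with Urotensin-2 receptor (Homo sapiens) as the target (on this read-out lower numbers stand for smaller maximal responses and higher numbers for larger maximal responses), compound 1 gives the highest of the three numbers. Compound 3 lies below it beyond the usual scatter, and compound 2 lies far lower, also beyond the scatter. Among the measured compounds shown here, no measured pair differs in a single place, so no step size is known directly.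

Compound 4 `Cc1ccccc1NC(=O)NC(CCN(C)C)c1ccc(Cl)cc1` differs from compound 1 in one place: (2-methylphenyl)amino in place of 2,3-dimethylphenyl on a carbonyl carbon. With nothing comparable among the measured pairs, the expectation rests on compound 1 alone. A moderate downward step is expected, possibly beyond the scatter, namely a number 34 percentage points lower from compound 1 to compound 4 (beyond the scatter). For compound 4 the estimated value is 125%, with a range from 75% to 170%.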

Compound 4, largest response reached (reported as efficacy), in percent of the reference or control that the assay uses: 175%
Compound 4: the middle estimate sits 50 percentage points below what was measured; the measured number lies above the stated range.
By their numbers in this assay, from the lowest: compound 2; then compound 3; then compound 1; then compound 4.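

In this assay, among the compounds shown here, this is the first change in a single place that can be sized: (2-methylphenyl)amino in place of 2,3-dimethylphenyl on a carbonyl carbon gives a number 16 percentage points higher from compound 1 to compound 4 (beyond the scatter), a modest step. The position therefore accepts an amino nitrogen and one more hydrogen-bond donor at the same heavy-atom count without the number falling. Nothing available accounts for the rise.

The compounds shown do not separate the entering nitrogen from the lost methyl, which a (2,3-dimethylphenyl)amino group on the same carbonyl carbon could do. As far as these compounds go, how a cyclohexylamino group would read here remains open.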